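Cytotoxicity of an oxadiazole analogue within one series

A few compounds are considered here, and "the series" means these few. Any claim that something is new, unique, unknown or untested is made for them only; others in the source may bear on it.

The series comprises compound 1 `CCO/N=C/c1cc(C)c(OCCC(C)CCN2CCN(c3ccnc(N)c3)C2=O)c(C)c1`, compound 2 `CCO/N=C/c1ccc(OCCC(C)CCN2CCN(c3ccnc(OC)c3)C2=O)cc1` and compound 3 `CCCc1nc(-c2cc(C)c(OCCC(C)CCN3CCN(c4ccnc(N)c4)C3=O)c(C)c2)no1`, the latter not yet tested. Within the data shown here, in an ADME assay on RD cells (Homo sapiens) for cytotoxicity, read by MTT assay, with a stated time of 24 h (on this read-out higher numbers stand for lower toxicity in this test and lower numbers for higher toxicity in this test), compound 1 gives 12900 nM, the only plain number among the two values shown. For compound 2 the same test reports only a limit, > 100000 nM, which is not a number (the limit of > 100000 nM in this assay, at which 1 of the 2 values shown sits). Compound 3 differs from compound 1 in one place: a group of 8 heavy atoms (5 carbon, 2 nitrogen, 1 oxygen; one five-membered aromatic ring with 3 hetero atoms) in place of a group of 5 heavy atoms (3 carbon, 1 nitrogen, 1 oxygen; no ring), on an aromatic carbon. Among the measured compounds shown here, no pair of measured compounds differing in a single place is available, so no measured step can guide the expectation. He therefore expects the step from compound 1 to compound 3 in this assay to be small, a 1.3-fold lower number from compound 1 to compound 3 (0.11 log units; within the scatter), in no clear direction and within the usual scatter. For compound 3 he estimates 10000 nM, between 4000 nM and 40000 nM.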

Compound 3, half-maximal cytotoxic concentration: 14100 nM
The estimate for compound 3 lay 1.4-fold (0.15 log units) below the measured number; low and high end bracket the measured number.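

Exchanging the open-chain group for 5-propyl-1,2,4-oxadiazol-3-yl, on the aromatic carbon meta to two methyl groups and para to a large group, gives a 1.1-fold higher number from compound 1 to compound 3 (0.04 log units; within the scatter) in this assay. Among these compounds, this is the first single-place step the series offers, and it shows that at this position a five-membered aromatic ring with 3 hetero atoms can stand in place of a group with no ring while the read-out stays within the usual scatter of repeated measurements. Nothing given here bears on why the two compounds read alike in this test.

A single step at one position leaves open whether other groups on this aromatic carbon, such as a carboxylic acid, an amine or a longer chain than the propyl on the oxadiazole, would also stay within the scatter in this assay. Among the compounds shown here, compound 2 has only a limit, > 100000 nM, which is not a number, and it differs from compound 1 and compound 3 in more than one place, so it supplies no step for this position.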